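The compounds below may be only part of what the source reports. "The series", "measured", "known", "first", "only" and "open" are said of these compounds alone.

Working notes on the benzimidazole-free description: the series is followed in a functional assay on ileum for inhibition of histamine H1 receptor (Cavia porcellus); a higher number here means a weaker inhibitor, a lower number a stronger inhibitor. Of the compounds shown here, two carry numbers so far. Compound 1 `CCNCCn1c(N2CCN(C)CC2)nc2ccccc21` gives 290 nM in this assay, the highest of the two numbers. Compound 2 `CCCN1CCN(c2nc3ccccc3n2CCOCC)CC1` gives 16 nM in this assay, a lower number than compound 1, a gap beyond the scatter. Among the measured compounds shown here, no single-change step between the two is recorded, as compound 2 differs from compound 1 in more than one place; the pair only shows that a chain without the ethylamino end can sit far lower in this assay.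

The next compound to be measured is compound 3 `CCCCCCCCCCn1c(N2CCN(C)CC2)nc2ccccc21`. Its change from compound 1 is octyl in place of ethylamino on a saturated chain carbon, two bonds along the chain from an aromatic nitrogen. The donor and acceptor of the ethylamino group are gone, and the chain grows by several carbons.

For the measured compounds named here, with no recorded step of this kind, the expectation rests on compound 2 with its 16 nM: a step downward from compound 1 is expected, a 4.1-fold lower number from compound 1 to compound 3 (0.62 log units; beyond the scatter), of moderate size and beyond the scatter. For compound 3 the estimate is 70 nM, with a range from 12 nM to 400 nM, and the number is expected to stay clear of any assay limit.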

Compound 3, half-maximal inhibitory concentration: 4200 nM
Compound 3: the middle estimate sits 60-fold (1.78 log units) below what was measured, outside the stated range (above it).
By their numbers in this assay, from the lowest: compound 2; then compound 1; then compound 3.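

In this assay, octyl in place of ethylamino on a saturated chain carbon, two bonds along the chain from an aromatic nitrogen, gives a 14-fold higher number from compound 1 to compound 3 (1.16 log units; beyond the scatter) as the first single-change step recorded at this position. The position therefore does not treat these two chain ends alike, and an all-carbon end with no hydrogen-bond donor or acceptor does not by itself bring the number down in this assay on the core of compound 1. Nothing measured on these compounds accounts for the size or direction of this step, and the change of end group and the growth of the chain remain tied together in it.

Left open is how the number depends on chain length alone, which a butyl chain on the core of compound 1 would begin to separate from the loss of the ethylamino group. Also open, from the compounds shown here alone, is whether the nitrogen of the ethylamino group matters as such, or whether a hydroxyl end or a dimethylamino end at the same place would sit closer to compound 1 than to compound 3 in this assay.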